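The compounds below may be only part of what the source reports. "The series", "measured", "known", "first", "only" and "open" are said of these compounds alone.

Compound 1 `Cc1ccc2[nH]c(-c3ccc(-c4ccc(-c5cccc(Cl)c5)cc4)cc3)nc2c1`: 2120 nM
Compound 2 `Clc1cccc(-c2ccc(-c3ccc(-c4nc5ccccc5[nH]4)cc3)cc2)c1`: 2190 nM
Compound 3 `Oc1cccc2[nH]c(-c3ccc(-c4ccc(-c5ccc(F)cc5)cc4)cc3)nc12`: 2860 nM

In a functional assay on Gurav cells (Homo sapiens) for inhibition, read by sulforhodamine B assay (on this read-out higher numbers stand for weaker inhibition of growth and lower numbers for stronger inhibition of growth), compound 1 gives 2120 nM. The values of compound 2 and compound 3 lie within the usual scatter of it, so the three cannot be ranked.

Compound 4 `Cc1ccc2[nH]c(-c3ccc(-c4ccc(-c5ccc(OC(F)(F)F)cc5)cc4)cc3)nc2c1` has not been measured yet. It keeps the core of compound 1 and carries 4-(trifluoromethoxy)phenyl in place of 3-chlorophenyl on an aromatic carbon.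

For the measured compounds named here, only one measured step exists, a 1.0-fold higher number from compound 1 to compound 2 (0.01 log units; within the scatter), and it is a different change, hydrogen in place of methyl. It stays within the scatter but says nothing direct about replacing the 3-chlorophenyl group. Compound 3, at 2860 nM, differs from compound 1 in more than one place, so it offers no clean comparison.

With so little evidence, no shift beyond the scatter is expected, and no direction can be argued. The estimated 1.2-fold higher number from compound 1 to compound 4 (0.07 log units; within the scatter) is therefore small. Compound 4 is expected at 2500 nM, with an estimated range from 1100 nM to 5500 nM.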

Compound 4, concentration for 50% growth inhibition: 11000 nM
Beside the measured number, compound 4's estimate is 4.4-fold (0.64 log units) below it, and the stated range ends below it.
By their numbers in this assay, from the lowest: compounds 1, 2 and 3 (each within the scatter of the next); then compound 4.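

In this assay, for the compounds shown here, replacing 3-chlorophenyl with 4-(trifluoromethoxy)phenyl gives a 5.2-fold higher number from compound 1 to compound 4 (0.72 log units; beyond the scatter) and is the first step in this set that clearly weakens growth inhibition. This shows that the group at this position matters for the read-out, which the earlier step could not show: a 1.0-fold higher number from compound 1 to compound 2 (0.01 log units; within the scatter) concerned a different place on the molecule and stayed within the scatter. No available measurement speaks to what lies behind this shift.

The change alters both the substituent and its place on the ring at once, so the compounds shown cannot separate those two contributions. On these data alone, it also remains open how growth inhibition would respond to an amine or a carboxylic acid on this ring.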